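The source may hold more compounds than are shown below. What is called first, only, known or untested is meant among the compounds shown, and "the series" means these compounds.

In a functional assay on HeLa cells (Homo sapiens) for cytotoxicity, read by MTT assay, with a stated time of 48 h (a lower number here means a stronger inhibitor, a higher number a weaker inhibitor), two compounds that share one core have been measured so far. Compound 1 `OC[C@@H]1C[C@H](CO)[C@@H]2C(c3ccc(Cl)cc3)=NO[C@H]12` gives > 50 ug/mL, which is a limit of the assay and not a number. Compound 2 `COc1ccc(C2=NO[C@@H]3[C@H](CO)C[C@H](CO)[C@H]23)cc1` gives > 50 ug/mL, which is also a limit, so its place in the series is known only as a limit. The picture so far is the limit of > 50 ug/mL in this assay, at which 2 of the 2 values shown sit.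

Compound 3 `OC[C@@H]1C[C@H](CO)[C@@H]2C(c3ccc(F)cc3)=NO[C@H]12` carries fluoro in place of methoxy on an aromatic carbon of the shared core, and the counted change is fluoro in place of methoxy on an aromatic carbon. Among the compounds with values here, the one measured step at this place is a step that the two limits leave unreadable from compound 1 to compound 2, with methoxy in place of chloro. That step has no readable size, so it offers no measured guide to the new exchange. With both neighbouring measurements at a limit, no step beyond the scatter is expected in this assay, and no direction can be assigned with confidence. The estimated step is a step that the limit leaves unreadable from compound 2 to compound 3. For compound 3 the expected value is 70 ug/mL, with an estimated range from 35 ug/mL to 150 ug/mL.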

Compound 3, half-maximal inhibitory concentration: > 50 ug/mL
Compound 3: a limit, no number; the forecaster's own chance of this, stated with the estimate: 80%; the middle value is on the limit's open side.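

In this assay, within the data shown here, compound 3 gives > 50 ug/mL, which is a limit and not a number, so no step among compound 1, compound 2 and compound 3 can be read. The series now stands as follows: the limit of > 50 ug/mL in this assay, at which 3 of the 3 values shown sit. The compounds shown leave open whether chloro, methoxy and fluoro on the aromatic carbon differ at all in this cytotoxicity read-out.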